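Compound 3 to compound 4: 4-chlorophenyl to 3-nitrophenyl

The compounds below may be only part of what the source reports. "The series", "measured", "known", "first", "only" and "open" are said of these compounds alone.

In a functional assay on A549 cells (Homo sapiens) for antiproliferative activity, read by CCK-8 assay, with a stated time of 72 h (a higher number here means a weaker inhibitor, a lower number a stronger inhibitor), compound 3 (`Cc1cc(Nc2cc(N3CCN(C)CC3)nc(Nc3ccc(Cl)cc3)n2)n[nH]1`) gives 631 nM and compound 2 (`Cc1cc(Nc2cc(N3CCN(C)CC3)nc(Nc3ccc([N+](=O)[O-])cc3)n2)n[nH]1`) gives 723 nM. These two values share the low end of the three measured numbers, and the step between them is a 1.1-fold lower number from compound 2 to compound 3 (0.06 log units; within the scatter). Compound 1 (`Cc1cc(Nc2cc(N3CCN(C)CC3)nc(Nc3ccc(S(N)(=O)=O)cc3)n2)n[nH]1`) gives 16700 nM, far from both, as shown by a 23-fold lower number from compound 1 to compound 2 (1.36 log units; beyond the scatter) and by a 26-fold lower number from compound 1 to compound 3 (1.42 log units; beyond the scatter).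

The next compound is compound 4 (`Cc1cc(Nc2cc(N3CCN(C)CC3)nc(Nc3cccc([N+](=O)[O-])c3)n2)n[nH]1`), still unmeasured. The change is 3-nitrophenyl in place of 4-chlorophenyl on a nitrogen on an aromatic ring, in words 3-nitrophenyl in place of 4-chlorophenyl on a nitrogen on an aromatic ring.

The closest evidence is the exchange of chloro and nitro between compound 2 and compound 3, which stayed within the scatter. The two large steps both involve the sulfamoyl group of compound 1, which plays no part in this change. Among the measured compounds shown here, no measured compound carries 3-nitrophenyl, so the series gives no direct reading of that group, and the range is kept wide. A small step is therefore expected in this assay, leaning towards a higher number. The expected step is a 1.6-fold higher number from compound 3 to compound 4 (0.20 log units; within the scatter). Compound 4 is estimated at 1000 nM, with a range of 350 nM to 3500 nM.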

Compound 4, half-maximal inhibitory concentration: 926 nM
Estimate against measurement, compound 4: 1.1-fold (0.03 log units) above; the range from low to high includes it.
By their numbers in this assay, from the lowest: compounds 3, 2 and 4 (each within the scatter of the next); then compound 1.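

In this assay, among the compounds shown here, the series now has a first reading on where the nitro group sits: 3-nitrophenyl in place of 4-nitrophenyl gives a 1.3-fold higher number from compound 2 to compound 4 (0.11 log units; within the scatter), and 3-nitrophenyl in place of 4-chlorophenyl gives a 1.5-fold higher number from compound 3 to compound 4 (0.17 log units; within the scatter), so compound 2, compound 3 and compound 4 all lie within the scatter of one another. For the compounds shown here, neither the place of the nitro group nor the exchange of nitro for chloro separates these compounds, while the 4-sulfamoylphenyl of compound 1 remains the only group here that stands apart, now also against the new group, with an 18-fold lower number from compound 1 to compound 4 (1.26 log units; beyond the scatter). Nothing measured on these compounds accounts for either the flat stretch or the gap to compound 1.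

Open, from the compounds shown here alone, is whether this flat stretch extends to other groups on the phenyl ring, such as an amine, a carboxylic acid or a longer alkoxy chain, or to a phenyl ring with no substituent at all. Going by these compounds, it is also open whether the gap belongs to sulfamoyl alone or would recur with a related group such as a methylsulfonyl or a carboxamide.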